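Swapping one five-membered ring for another in two close analogues

A few compounds are considered here, and "the series" means these few. Any claim that something is new, unique, unknown or untested is made for them only; others in the source may bear on it.

Compound 1 `c1c[nH]c(-c2ccccc2OCC2=NCCN2)c1`: 111%
Compound 2 `c1ccc(-c2ccsc2)c(OCC2=NCCN2)c1`: 120%

In a functional assay with Alpha-1D adrenergic receptor (Homo sapiens) as the target, read by calcium flux (on this read-out higher numbers stand for larger maximal responses and lower numbers for smaller maximal responses), compound 1 gives 111%. In this assay compound 2 gives 120%. For the measured compounds named here, the only measured step between them is a number 9 percentage points higher from compound 1 to compound 2 (within the scatter), so the two numbers lie within the usual scatter of each other and neither compound can be set apart from the other on this read-out.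

Compound 3 `c1ccc(-c2nccs2)c(OCC2=NCCN2)c1` is not yet measured. It differs from compound 2 in one place: 1,3-thiazol-2-yl in place of thiophen-3-yl on an aromatic carbon. Going by the values given here, the single measured step, from compound 1 to compound 2, bears on this change, since it too exchanged one five-membered aromatic ring for another at the same position, and it stayed within the scatter. On that basis no step beyond the scatter is expected here either, and the expected change is a number 5 percentage points lower from compound 2 to compound 3 (within the scatter). Compound 3 is therefore estimated to give 115% in this assay, with a likely range from 95% to 135%.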

Compound 3, largest response reached (reported as maximum), in percent of the reference or control that the assay uses: 113%
For compound 3 the middle estimate is 2 percentage points above the measured one, within the range that was stated.
By their numbers in this assay, from the lowest: compounds 1, 3 and 2 (each within the scatter of the next).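

In this assay, 1,3-thiazol-2-yl in place of thiophen-3-yl gives a number 7 percentage points lower from compound 2 to compound 3 (within the scatter), and 1,3-thiazol-2-yl in place of 1H-pyrrol-2-yl gives a number 2 percentage points higher from compound 1 to compound 3 (within the scatter). For the compounds shown here, the earlier pair showed one five-membered aromatic ring exchanged for another, whereas this result adds a ring with 2 hetero atoms and 2 hydrogen-bond acceptors in place of thiophen-3-yl with 1 of each, and even this difference in ring make-up produces no step that can be told from the scatter. All three compounds therefore sit within the scatter of one another at this position, on an aromatic carbon ortho to a group of 7 heavy atoms, and no available evidence offers an explanation for this result.

From the compounds shown here alone, all the groups compared so far are five-membered aromatic rings, so it remains open whether a six-membered ring such as phenyl or pyridyl, a simple amine, a carboxylic acid or a longer alkyl chain at this position would also stay within the scatter. Going by these compounds, it is also open whether removing the ring altogether, leaving only hydrogen on that carbon, would change the maximal response.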